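This account rests on a few compounds, and the source may have more. Where it says the series, first, only, none or still open, it means among the compounds named here.

In a functional assay (Platelet, plasma) for inhibition, with Homo sapiens as the target (a lower number here means a stronger inhibitor, a higher number a weaker inhibitor), compound 3 `N#Cc1cc2c(nc1N1CCC(C(=O)NS(=O)(=O)c3ccc(Cl)s3)CC1)COC2=O` gives 4470 nM. Compound 2 `N#Cc1ccc(CS(=O)(=O)NC(=O)C2CCN(c3nc4c(cc3C#N)C(=O)OC4)CC2)cc1` gives 8900 nM, within the scatter of compound 3, while compound 1 `CC1(C(=O)NS(=O)(=O)Cc2ccc(F)cc2)CCN(c2nc3c(cc2C#N)C(=O)OC3)CC1` gives 35400 nM, clearly higher than the number for compound 3. Compound 3 therefore shares the low end of this small set with compound 2.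

The next structure, compound 4 `N#Cc1cc2c(nc1N1CCC(C(=O)NS(=O)(=O)Cc3ccc(F)cc3)CC1)COC2=O`, differs from compound 3 only in the group on the sulfonyl sulfur: 4-fluorobenzyl in place of 5-chlorothiophen-2-yl on a sulfonyl sulfur. In words, 4-fluorobenzyl stands in place of 5-chlorothiophen-2-yl.

Among the measured compounds shown here, the one measured step at this place is a 2.0-fold lower number from compound 2 to compound 3 (0.30 log units; within the scatter). It replaces 4-cyanobenzyl with 5-chlorothiophen-2-yl, so it runs the opposite way from the present change, from a benzyl group to the thiophene. Compound 1 carries the same 4-fluorobenzyl but also differs from compound 4 elsewhere, so it offers only a loose upper guide.

In this assay a modest move to a higher number is expected, of about the size of that single step and not clearly beyond the scatter. The estimated change is a 2.0-fold higher number from compound 3 to compound 4 (0.30 log units; within the scatter). For compound 4 the expected value is 9000 nM, with an estimated range from 3500 nM to 23000 nM.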

Compound 4, half-maximal inhibitory concentration: 3500 nM
Estimate against measurement, compound 4: 2.6-fold (0.41 log units) above; low and high end bracket the measured number.
By their numbers in this assay, from the lowest: compounds 4, 3 and 2 (each within the scatter of the next, the first and the last beyond it); then compound 1.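

In this assay, the exchange at the sulfonyl sulfur is a 1.3-fold lower number from compound 3 to compound 4 (0.11 log units; within the scatter), so this pair does not separate 4-fluorobenzyl from 5-chlorothiophen-2-yl, and the earlier comparison of the thiophene with a benzyl group, which involved 4-cyanobenzyl, now has a second benzyl partner. Within the benzyl pair, fluoro in place of cyano on an aromatic carbon gives a 2.5-fold lower number from compound 2 to compound 4 (0.41 log units; beyond the scatter), a modest step but the first at this place that lies beyond the scatter, even though compound 3 remains within the scatter of both compound 2 and compound 4. Among the compounds shown here, the new compound also isolates the methyl on the saturated ring carbon for the first time, with hydrogen in its place giving a 10-fold lower number from compound 1 to compound 4 (1.00 log units; beyond the scatter), a modest step beyond the scatter that shows the series responds to this site as well as to the sulfonyl substituent.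

No measurement offered here accounts for any of these steps. Still open, as far as these compounds go, are how a carboxylic acid or an amine on the aromatic ring, or a longer chain in place of the benzyl group on the sulfonyl sulfur, would read in this assay, and whether removing the methyl gives a similar step with 5-chlorothiophen-2-yl or 4-cyanobenzyl on the sulfur.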